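Aryloxy in place of benzylamino on the shared core

The source may hold more compounds than are shown below. What is called first, only, known or untested is meant among the compounds shown, and "the series" means these compounds.

Measured compounds:
compound 1 `O=C1CCCN1CCCNc1ncccc1-c1n[nH]c(Nc2ccc3c(c2)OCCO3)n1`: "not determined" (no result reported)
compound 2 `COc1ccc(CNc2ncccc2-c2n[nH]c(Nc3ccc4c(c3)OCCO4)n2)cc1`: 30%

In a functional assay on A-431 cells (Homo sapiens), tested at 0.1 uM (a lower number here means less inhibition, a higher number more inhibition at the concentration tested (going by the name of the read-out)), compound 1 gives "not determined" (no result reported), so it carries no number. In this assay, within the data shown here, compound 2 gives 30%, the only value, so it stands alone with nothing to compare against. Compound 3 `COc1cc(OC)cc(Oc2ncccc2-c2n[nH]c(Nc3ccc4c(c3)OCCO4)n2)c1` is still unmeasured and differs from compound 2 in one place: 3,5-dimethoxyphenoxy in place of (4-methoxybenzyl)amino on an aromatic carbon. Among the measured compounds shown here, no step between measured compounds is known, so the size of this change cannot be read from data. A modest decrease, just beyond the scatter, seems the likeliest expectation. Compound 3 is estimated at 18%, range 3% to 42%. The expected step is a number 12 percentage points lower from compound 2 to compound 3 (beyond the scatter).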

Compound 3, a percentage reported as inhibition, at one concentration (the size of the read-out at that concentration, not a potency): 89%
Compound 3: middle estimate off by 71 percentage points, on the low side; the measured number lies above the stated range.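

In this assay there is a number 59 percentage points higher from compound 2 to compound 3 (beyond the scatter) when 3,5-dimethoxyphenoxy replaces (4-methoxybenzyl)amino on the aromatic carbon next to the ring nitrogen. This shows that the group at this position can strongly change inhibition at the tested concentration, which compound 2 alone could not show. No available evidence explains the size of this step. The compounds shown leave open whether the linking atoms or the methoxy pattern carries the step; 4-methoxyphenoxy or (3,5-dimethoxybenzyl)amino at this position would separate the two.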